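A few compounds are considered here, and "the series" means these few. Any claim that something is new, unique, unknown or untested is made for them only; others in the source may bear on it.

Measured in a functional assay on cells (Neutrophil, Homo sapiens) for inhibition, with a stated time of 10 min; a higher number here means a weaker inhibitor, a lower number a stronger inhibitor:
- Compound 1 `O=C(Nc1cccc(F)c1)N1c2ccnn2CC1c1ccccc1`: > 1000 nM, a limit of the assay and not a number
- Compound 2 `CCOC(=O)c1cnn2c1N(C(=O)Nc1cccc(F)c1)C(c1ccccc1)C2`: 111 nM
- Compound 3 `O=C(NC1CC1)c1cnn2c1N(C(=O)Nc1ccccc1)C(c1ccccc1)C2`: 13.2 nM

Compound 3 has the lowest number of the series, and its gap to compound 2 lies beyond the scatter. Compound 4 `O=C(NC1CC1)c1cnn2c1N(C(=O)Nc1cccc(F)c1)C(c1ccccc1)C2` is not yet measured. It differs from compound 3 by one change, (fluoro in place of hydrogen on an aromatic carbon), which is fluoro in place of hydrogen on an aromatic carbon, turning phenylcarbamoyl to (3-fluorophenyl)carbamoyl.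

For the measured compounds named here, no measured step makes this change alone. Going by the values given here, the only measured step, an at least 9.0-fold lower number from compound 1 to compound 2 (0.95 log units; beyond the scatter), is a different change, ethoxycarbonyl in place of hydrogen on an aromatic carbon, and both of its compounds already carry the fluoro. Compounds 2 and 3 differ in more than one place, so their gap cannot be assigned to the fluoro. With so little to go on, the expected change is small, a 1.4-fold higher number from compound 3 to compound 4 (0.13 log units; within the scatter), which is expected to stay within the scatter. For compound 4 the estimated value is 18 nM, with an expected range from 5 nM to 70 nM.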

Compound 4, half-maximal inhibitory concentration: > 1000 nM
Compound 4: no number, only a limit; the forecaster's own chance of this, stated with the estimate: 3%; at least 55-fold (1.74 log units) between middle value and limit.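

The earlier compounds shown here all left the effect of the fluoro unseen, but here, in this assay, turning phenylcarbamoyl to (3-fluorophenyl)carbamoyl and changing nothing else gives an at least 75-fold higher number from compound 3 to compound 4 (1.87 log units; beyond the scatter), so one added fluorine atom at this position is enough to lose nearly all measurable inhibition in the cyclopropylcarbamoyl series. The 3-fluorophenyl group does not rule out inhibition on its own, since cyclopropylamino in place of ethoxy, with the fluoro kept, gives an at least 9.0-fold higher number from compound 2 to compound 4 (0.95 log units; beyond the scatter), and compound 2 reads 111 nM. The value of compound 4, > 1000 nM, is a limit of the assay and not a number: the limit of > 1000 nM in this assay, at which 2 of the 4 values shown sit.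

The step from compound 1 to compound 4 cannot be read. On these data alone, whether a chloro or a methyl group at this same position would cost as much as the fluoro remains open.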